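The source may hold more compounds than are shown below. What is called first, only, known or untested is meant among the compounds shown, and "the series" means these compounds.

Values in an ADME assay on microsomes from liver (Homo sapiens) for metabolic stability; on this read-out lower numbers stand for a shorter-lived compound and higher numbers for a longer-lived compound:

- Compound 1 `CCS(=O)(=O)c1ccc(CNC(=O)c2ccc3c(c2)cc(Cc2ccccc2C(F)(F)F)n3C(C)C)cc1`: 0.65 h
- Compound 2 `CCS(=O)(=O)c1ccc(CNC(=O)c2ccc3c(c2)cc(Cc2ccc(F)cc2C(F)(F)F)n3C(C)C)cc1`: 1.2 h
- Compound 3 `CCc1ccccc1Cc1cc2cc(C(=O)NCc3ccc(S(=O)(=O)CC)cc3)ccc2n1C(C)C`: not yet measured

Within the data shown here, compound 2 stands at 1.2 h, within the scatter of compound 1, the only other measured compound. The next structural change is 2-ethylphenyl in place of 4-fluoro-2-(trifluoromethyl)phenyl on a saturated chain carbon bound to an aromatic carbon. In words, this places 2-ethylphenyl in place of 4-fluoro-2-(trifluoromethyl)phenyl on a saturated chain carbon bound to an aromatic carbon.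

Among the measured compounds shown here, only one measured step bears on this change: a 1.8-fold higher number from compound 1 to compound 2 (0.27 log units; within the scatter), with fluoro in place of hydrogen on an aromatic carbon. That step lies within the scatter. For the measured compounds named here, no measured step isolates the loss of trifluoromethyl or the entry of ethyl, so the evidence is thin. Like compound 3, compound 1 has no fluoro on an aromatic carbon, and compound 1 gives 0.65 h, which serves as the anchor for the expectation. The expected step in this assay is small and toward a shorter-lived compound: a 1.8-fold lower number from compound 2 to compound 3 (0.27 log units; within the scatter). The estimated half-life of compound 3 is 0.65 h, with an expected range of 0.25 h to 1.4 h.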

Compound 3, half-life: 0.217 h
The estimate for compound 3 lay 3.0-fold (0.48 log units) above the measured number; the whole stated range lies above it.
By their numbers in this assay, from the lowest: compound 3; then compounds 1 and 2 (each within the scatter of the next).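

In this assay, ethyl in place of trifluoromethyl on an aromatic carbon gives a 3.0-fold lower number from compound 1 to compound 3 (0.48 log units; beyond the scatter) and is the cleanest reading of this position, since no fluoro enters that comparison and the step lies beyond the scatter, unlike the earlier fluoro step. The full exchange of 4-fluoro-2-(trifluoromethyl)phenyl for 2-ethylphenyl on a saturated chain carbon bound to an aromatic carbon gives a 5.5-fold lower number from compound 2 to compound 3 (0.74 log units; beyond the scatter) in the same direction, so both compounds carrying trifluoromethyl give higher numbers than compound 3 and the substituent on this ring clearly registers on the half-life read-out. Nothing shown explains why the number falls with this change.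

Still open, on these data alone, is whether ethyl itself sets the lower number or whether a methyl, a methoxy, a chlorine or a nitrile in its place would read the same way, as these three compounds cover only trifluoromethyl and ethyl on that carbon. Among these compounds, also open is whether fluoro on the 2-ethylphenyl ring would shift the number at all, given that the only fluoro step so far stands within the scatter and on the trifluoromethyl ring.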